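Benzhydryl extension at the indole nitrogen

The source may hold more compounds than are shown below. What is called first, only, known or untested is meant among the compounds shown, and "the series" means these compounds.

Compound 1 `CCCCn1ccc2cc(/C(C)=C/C(=O)Nc3ccccc3OCCCC(=O)O)ccc21`: in an assay on Prostate gland for inhibition of steroid 5-alpha-reductase (Rattus norvegicus) (a lower number here means a stronger inhibitor, a higher number a weaker inhibitor), compound 1 gives 43 nM
Compound 2 `C/C(=C\C(=O)Nc1ccccc1OCCCC(=O)O)c1ccc2c(ccn2Cc2ccc(C(F)(F)F)cc2)c1`: in this assay compound 2 gives 300 nM
Compound 3 `COc1ccc(Cn2ccc3cc(/C(C)=C/C(=O)Nc4ccccc4OCCCC(=O)O)ccc32)cc1`: in this assay compound 3 gives 480 nM

Among the three measured compounds, compound 3 carries the highest number in this assay; its nearest neighbour is compound 2, and the gap between them lies within the scatter, while the gap to compound 1 lies beyond it. Compound 4 `COc1ccc(C(c2ccccc2)n2ccc3cc(/C(C)=C/C(=O)Nc4ccccc4OCCCC(=O)O)ccc32)cc1` differs from compound 3 by phenyl in place of hydrogen on a saturated chain carbon bound to an aromatic carbon and an aromatic nitrogen.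

Within the data shown here, no measured step covers this exact change. Among the measured compounds shown here, the steps that bear on substitution at the same chain carbon are a 7.0-fold higher number from compound 1 to compound 2 (0.84 log units; beyond the scatter) and an 11-fold higher number from compound 1 to compound 3 (1.05 log units; beyond the scatter), both of which replaced propyl with an aryl group and gave a clearly higher number. The step of a 1.6-fold higher number from compound 2 to compound 3 (0.20 log units; within the scatter) shows that the two aryl variants sit close together. Adding a further phenyl to that carbon is therefore expected to give a modestly higher number, or one not clearly beyond the scatter of compound 3. Compound 4 is estimated to give 800 nM in this assay, with a range from 250 nM to 2500 nM, corresponding to an expected step of a 1.7-fold higher number from compound 3 to compound 4 (0.22 log units; within the scatter).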

Compound 4, half-maximal inhibitory concentration: 8.8 nM
For compound 4 the middle estimate is 91-fold (1.96 log units) above the measured one; the measured number lies below the stated range.
By their numbers in this assay, from the lowest: compound 4; then compound 1; then compounds 2 and 3 (each within the scatter of the next).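

In this assay, phenyl in place of hydrogen on the saturated chain carbon bound to an aromatic carbon and an aromatic nitrogen gives a 55-fold lower number from compound 3 to compound 4 (1.74 log units; beyond the scatter) and so moves the series in the opposite direction from the earlier changes at this carbon. Those earlier changes, aryl groups in place of propyl, had only raised the number, whereas the same carbon carrying two aryl groups gives the lowest number shown, so one aryl group there says little about what two will do. The data shown offer no measured reason for a step of this size.

Going by these compounds, it remains open whether the methoxy group still matters once this carbon carries two aryl groups, or whether trifluoromethyl would serve equally well in its place. On these data alone, it is also open whether a cyclohexyl or a methyl group on that carbon would do what the phenyl does.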